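A few compounds are considered here, and "the series" means these few. Any claim that something is new, unique, unknown or untested is made for them only; others in the source may bear on it.

Readings in a functional assay on cells (Neutrophil, Homo sapiens), with a stated time of 5 min (a lower number here means a stronger inhibitor, a higher number a weaker inhibitor), so far:

compound 1 (`COc1cc([C@H]2Oc3c(OC)cc(/C=C/C=O)cc3[C@@H]2CO)cc(OC)c1O`) gives 19300 nM
compound 2 (`CC(C)(O)[C@H](O)COc1ccc(/C=C/CO)cc1`) gives 32600 nM
compound 3 (`COc1cc([C@@H]2Oc3c(OC)cc(/C=C/CO)cc3[C@H]2CO)cc(OC)c1O`) gives 11800 nM

Compound 1 stands within the scatter of both compound 3 and compound 2, so no ranking around it is drawn from these numbers. Compound 4 (`COc1cc([C@H]2Oc3c(OC)cc(/C=C/C=O)cc3[C@@H]2CO)ccc1O`) keeps the core of compound 1 and is still to be measured. The change hydrogen in place of methoxy on an aromatic carbon puts hydrogen in place of methoxy on an aromatic carbon, ortho to a hydroxy group and meta to a methoxy group.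

Going by the values given here, no measured pair isolates this change, so the series offers no direct guide to its size or direction. Only an indirect argument is available. Compound 2 at 32600 nM has a clearly different structure yet remains within the scatter of compound 1 in this assay. A single methoxy group lost from compound 1 is therefore expected to cause no shift beyond the scatter, with no firm direction.

The expected change is a 1.1-fold lower number from compound 1 to compound 4 (0.06 log units; within the scatter) as an estimate, which stays within the scatter. For compound 4 the estimated value is 17000 nM with an expected range from 7000 nM to 40000 nM in this measurement.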

Compound 4, half-maximal inhibitory concentration: 31900 nM
Compound 4: middle estimate off by 1.9-fold (0.27 log units), on the low side; the measured number falls inside the stated range.
By their numbers in this assay, from the lowest: compounds 3, 1, 4 and 2 (each within the scatter of the next, the first and the last beyond it).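

Hydrogen in place of methoxy on an aromatic carbon, ortho to a hydroxy group and meta to a methoxy group, gives the first step in the series that isolates one place: in this assay it reads a 1.7-fold higher number from compound 1 to compound 4 (0.22 log units; within the scatter) and so stays inside the usual spread of repeats. With compound 1 and compound 4 held to the same core, this methoxy group is not shown to be needed for a reading in this range, and the earlier compounds, which differ in more than one place, could not show that. The step gives no reliable direction, and no measurement on hand bears on why the two compounds read alike.

As far as these compounds go, only methoxy and hydrogen have been seen at this position, so it remains open whether an amine, a carboxylic acid, a fluorine atom or a longer chain such as butoxy would move the reading beyond the scatter. Going by these compounds alone, also open is whether the same exchange would read alike in a compound carrying the side chain of compound 3, since no pair tests the change on that chain.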